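Aryl exchange on the shared core: outlook for compound 4

This account rests on a few compounds, and the source may have more. Where it says the series, first, only, none or still open, it means among the compounds named here.

Measured compounds:
compound 1, `COc1cc(NC(=O)Nc2cc(Nc3cccc(C(C)(C)C)c3)ncn2)cc(OC)c1`, in a functional assay on NCI-H520 cells (Homo sapiens) for inhibition, read by MTT assay, with a stated time of 48 h, tested at 10 uM (a higher number here means more inhibition at the concentration tested (going by the name of the read-out), a lower number less inhibition), compound 1 gives 13.1%
compound 2, `COc1cc(NC(=O)Nc2cc(Nc3cc(F)ccc3OC)ncn2)cc(OC)c1`, compound 2 gives 38%
compound 3, `CCc1cccc(Nc2cc(NC(=O)Nc3cc(OC)cc(OC)c3)ncn2)c1`, compound 3 gives 23%

Compound 3 stands second highest of the three numbers: its nearest neighbour is compound 1, with a number 9.9 percentage points higher from compound 1 to compound 3 (within the scatter), and its furthest is compound 2, with a number 15 percentage points lower from compound 2 to compound 3 (beyond the scatter).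

Compound 4, `COc1cc(NC(=O)Nc2cc(Nc3ccc(OC)c(I)c3)ncn2)cc(OC)c1`, differs from compound 3 by 3-iodo-4-methoxyphenyl in place of 3-ethylphenyl on a nitrogen on an aromatic ring.

Among the measured compounds shown here, the steps that bear on this are those that exchange the group on this nitrogen: a number 24.9 percentage points higher from compound 1 to compound 2 (beyond the scatter) and a number 15 percentage points lower from compound 2 to compound 3 (beyond the scatter). Both place the group that carries a methoxy higher than the group without one. The entering group also carries a methoxy, and a modest rise is therefore expected, a number 9 percentage points higher from compound 3 to compound 4 (within the scatter). Compound 4 is estimated at 32%, with a range from 15% to 50%.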

Compound 4, a percentage reported as inhibition, at one concentration (the size of the read-out at that concentration, not a potency): 46.5%
For compound 4 the middle estimate is 14.5 percentage points below the measured one; the range from low to high includes it.
By their numbers in this assay, from the lowest: compounds 1 and 3 (each within the scatter of the next); then compounds 2 and 4 (each within the scatter of the next).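

In this assay, the split on this nitrogen now holds for a second methoxy-bearing group: 3-iodo-4-methoxyphenyl stands clear of both groups without a methoxy (a number 23.5 percentage points higher from compound 3 to compound 4 (beyond the scatter); a number 33.4 percentage points higher from compound 1 to compound 4 (beyond the scatter)). Against 5-fluoro-2-methoxyphenyl, the exchange cannot be told apart from scatter (a number 8.5 percentage points higher from compound 2 to compound 4 (within the scatter)), so these two different arrangements of ring groups read alike here. Nothing available explains these steps.

Open, as far as these compounds go, is whether the methoxy alone accounts for the split or whether the iodine or fluorine also contributes. Also open, from the compounds shown here alone, is how an amine or a carboxylic acid on this aromatic ring would read.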